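The source may report more compounds than this note shows. Statements on the series, on what has been measured and on what is new or still open speak of the compounds shown alone.

Working notes on the series in a functional assay on K562 cells (Homo sapiens) for inhibition, read by sulforhodamine B assay, with a stated time of 48 h; on this read-out lower numbers stand for stronger inhibition of growth and higher numbers for weaker inhibition of growth. Compound 1 `O=C(Cc1csc2nc(-c3ccc(Br)cc3)cn12)N/N=C/c1ccccc1` gives 7940 nM, compound 2 `O=C(Cc1csc2nc(-c3ccc(Br)cc3)cn12)N/N=C/c1ccccc1O` gives 2950 nM, and compound 3 `O=C(Cc1csc2nc(-c3ccc(Br)cc3)cn12)N/N=C/c1ccc(O)cc1` gives 7080 nM. Compound 3 thus stands within the scatter of compound 1, and compound 2 is the only one of the three clearly lower.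

Compound 4 `COc1cccc(OC)c1/C=N/NC(=O)Cc1csc2nc(-c3ccc(Br)cc3)cn12` differs from compound 3 as follows: 2,6-dimethoxyphenyl in place of 4-hydroxyphenyl on a carbon with a double bond to nitrogen. In words, this is 2,6-dimethoxyphenyl in place of 4-hydroxyphenyl on a carbon with a double bond to nitrogen.

Within the data shown here, no measured compound carries this group, so the evidence is indirect. The nearest guide is the set of measured changes on the same ring: a 2.7-fold lower number from compound 1 to compound 2 (0.43 log units; beyond the scatter), a 2.4-fold higher number from compound 2 to compound 3 (0.38 log units; beyond the scatter) and a 1.1-fold lower number from compound 1 to compound 3 (0.05 log units; within the scatter). The first two are modest and the third is within the scatter. In this assay no step beyond the scatter is therefore expected, with a slight lean towards a lower number.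

The expected step is a 1.4-fold lower number from compound 3 to compound 4 (0.15 log units; within the scatter). For compound 4 the estimated value is 5000 nM, with an expected range of 2000 nM to 12000 nM.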

Compound 4, concentration for total growth inhibition: 6920 nM
Beside the measured number, compound 4's estimate is 1.4-fold (0.14 log units) below it; low and high end bracket the measured number.
By their numbers in this assay, from the lowest: compound 2; then compounds 4, 3 and 1 (each within the scatter of the next).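

In this assay, 2,6-dimethoxyphenyl on a carbon with a double bond to nitrogen stays level with 4-hydroxyphenyl, with a 1.0-fold lower number from compound 3 to compound 4 (0.01 log units; within the scatter), and with phenyl, with a 1.1-fold lower number from compound 1 to compound 4 (0.06 log units; within the scatter). Against the 2-hydroxyphenyl group the result is a 2.3-fold higher number from compound 2 to compound 4 (0.37 log units; beyond the scatter), so the two methoxy groups do not carry over the lower number seen with compound 2. This place therefore accepts 2,6-dimethoxyphenyl, with 0 hydrogen-bond donors, without a step beyond the scatter from compound 1 or compound 3, and compound 2 remains the only one of the four clearly lower.

No evidence is at hand on why compound 2 stands apart. Going by these compounds, whether 2-methoxyphenyl alone, or a ring bearing an amine or a carboxylic acid, would follow compound 2 or the other three remains open.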